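The source may report more compounds than this note shows. Statements on the series, on what has been measured and on what is new or still open speak of the compounds shown alone.

Measured compounds:
- compound 1, `Cn1nc(Cc2nnc(SCCCCCCCC(=O)Nc3ccc(Cl)cc3Cl)n2CCC=O)c2ccccc2c1=O`: 2500 nM
- compound 2, `CN(C)CCCn1nc(Cc2nnc(SCCCCCCCC(=O)Nc3ccc(Cl)cc3Cl)n2C)c2ccccc2c1=O`: 2300 nM

In an assay on 32D cells for inhibition of interleukin-15 (Mus musculus), read by resazurin assay, with stated times of 30 min and 2.5 days, in the presence of a further agent that is not named here (a higher number here means a weaker inhibitor, a lower number a stronger inhibitor), compound 2 gives 2300 nM, and compound 1 gives 2500 nM; the two numbers lie within the usual scatter of each other, so neither compound can be called the stronger inhibitor.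

Compound 3, `Cn1c(Cc2n[nH]c(=O)c3ccccc23)nnc1SCCCCCCCC(=O)Nc1ccc(Cl)cc1Cl`, has not yet been measured. It differs from compound 2 in one place: hydrogen in place of 3-(dimethylamino)propyl on an aromatic nitrogen, that is, a hydrogen in place of 3-(dimethylamino)propyl on an aromatic nitrogen of a six-membered aromatic ring within a fused system of two rings.

Among the compounds with values here, no step between two measured compounds is available to anchor this change. Compound 1 and compound 2 carry different groups at that same aromatic nitrogen yet give near-identical numbers, which suggests that the site tolerates variation. The expected step from compound 2 to compound 3 in this assay is therefore a 1.1-fold higher number from compound 2 to compound 3 (0.04 log units; within the scatter), none beyond the scatter. Compound 3 is estimated at 2500 nM, in the range 1000 nM to 6500 nM.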

Compound 3, half-maximal inhibitory concentration: > 30000 nM
Compound 3: no number, only a limit; the forecaster's own chance of this, stated with the estimate: 10%; middle value at least 12-fold (1.07 log units) away from the limit.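

Putting hydrogen in place of 3-(dimethylamino)propyl on this aromatic nitrogen gives an at least 13-fold higher number from compound 2 to compound 3 (1.11 log units; beyond the scatter). Both earlier compounds carry a group on this nitrogen, so they could not show that the bare position behaves so differently in this assay: here, the group on the nitrogen matters a great deal. The size of the step is a lower bound, as the value for compound 3 is a limit of the assay and not a number: the limit of > 30000 nM in this assay, at which 1 of the 3 values shown sits.

The compounds shown leave open whether the dimethylamino end of the chain matters or simply the presence of some group on this nitrogen. A plain propyl chain, a lone methyl or a chain ending in a carboxylic acid, each on the otherwise unchanged structure of compound 2, would help to separate these possibilities.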